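A few compounds are considered here, and "the series" means these few. Any claim that something is new, unique, unknown or untested is made for them only; others in the source may bear on it.

Measured compounds:
- compound 1 `COc1ccc(OC(=O)Nc2ccc([Se]C#N)cc2)cc1`: 69600 nM
- compound 2 `CCCOC(=O)Nc1ccc([Se]C#N)cc1`: 75400 nM

In a functional assay on HT-29 cells (Homo sapiens) for cytotoxicity, read by MTT assay, with a stated time of 72 h (a lower number here means that less compound is tolerated, a higher number that more compound is tolerated), compound 1 gives 69600 nM and compound 2 gives 75400 nM; the two numbers lie within the usual scatter of each other, so compound 2 is not set apart from compound 1 in this assay. Compound 3 `CC(C)COC(=O)Nc1ccc([Se]C#N)cc1` carries methyl in place of hydrogen on a saturated chain carbon bound to two saturated chain carbons. For the measured compounds named here, no step between measured compounds covers a change of this kind, so there is nothing to show a shift; the expectation is a step of a 1.0-fold lower number from compound 2 to compound 3 (0.00 log units; within the scatter) of no size beyond the scatter in this assay. Compound 3 is estimated at 75000 nM, range 35000 nM to 160000 nM.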

Compound 3, concentration lethal to 50% of the cells: 63700 nM
For compound 3 the middle estimate is 1.2-fold (0.07 log units) above the measured one; the measured number falls inside the stated range.
By their numbers in this assay, from the lowest: compounds 3, 1 and 2 (each within the scatter of the next).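

Propyl to isobutyl, the only change examined at this chain carbon, gives a 1.2-fold lower number from compound 2 to compound 3 (0.07 log units; within the scatter) in this assay. Methyl in place of hydrogen at this position therefore does not set compound 3 apart from compound 2, and a branch here is tolerated without a step beyond the scatter. Nothing available explains this result.

Open, as far as these compounds go, is whether a longer chain, a cyclohexyl ring or a terminal amine at this end of the molecule would give a step beyond the scatter in this assay. From the compounds shown here alone, a carboxylic acid on the chain remains equally open.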